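Chloro Added to Compound 2: Expected Tolerance in Cells

A few compounds are considered here, and "the series" means these few. Any claim that something is new, unique, unknown or untested is made for them only; others in the source may bear on it.

Measured compounds:
Compound 1, `CCc1ccc2[nH]c(=O)c(CN(Cc3ccc(O)cc3)Cc3ccc(C(C)(C)C)cc3)cc2c1`: > 10000 nM in a toxicity assay on MDCK cells (Canis lupus familiaris) for cytotoxicity, read by crystal violet staining, with a stated time of 48 h; a lower number here means that less compound is tolerated, a higher number that more compound is tolerated
Compound 2, `CCc1ccc2[nH]c(=O)c(CN(Cc3ccc(C(C)(C)C)cc3)C(C)c3ccc(OC)cc3)cc2c1`: > 5000 nM in this assay

Both numbers are limits of this assay rather than measured values. Compound 1 sits at the limit (the limit of > 10000 nM in this assay, at which 1 of the 2 values shown sits). Compound 2 sits at the limit (the limit of > 5000 nM in this assay, at which 1 of the 2 values shown sits). Compound 2 therefore stands only at a limit: up to that concentration no half-maximal loss of cells was seen. Among the compounds with values here, the one step between measured compounds, a step that the two limits leave unreadable from compound 1 to compound 2, is 1-(4-methoxyphenyl)ethyl in place of 4-hydroxybenzyl on an amine nitrogen; both values are limits, so its size cannot be read.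

Compound 3, `CCc1ccc2[nH]c(=O)c(CN(Cc3ccc(C(C)(C)C)cc3)C(C)c3ccc(OC)c(Cl)c3)cc2c1`, has not yet been measured in this assay. It differs from compound 2 by chloro in place of hydrogen on an aromatic carbon, ortho to a methoxy group and meta to a large group. Within the data shown here, no measured step involves a chloro group, and the single known step is unreadable, so no direction beyond the scatter can be expected. The step from compound 2 is estimated as a step that the limit leaves unreadable from compound 2 to compound 3. Compound 3 is expected to give 8000 nM, within 3000 nM to 20000 nM, most likely again only as a limit.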

Compound 3, half-maximal cytotoxic concentration: > 10000 nM
Compound 3: no number, only a limit (the forecaster's own chance of this, stated with the estimate: 70%); middle value at least 1.2-fold (0.09 log units) from the limit.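

In this assay compound 3 gives > 10000 nM, which is a limit and not a number. Compound 1 and compound 2 also stand only at limits, so neither step to compound 3 can be read. The compounds shown leave open the concentration at which any of them would cause half-maximal cell loss, and whether chloro changes tolerance.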